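Trifluoromethyl for Methyl: Expected Cytotoxicity of Compound 4

The compounds below may be only part of what the source reports. "The series", "measured", "known", "first", "only" and "open" are said of these compounds alone.

Compound 1 `Cc1cc(Nc2nnc(Cc3c(Cl)cccc3Cl)o2)ccc1Cl` was tested in a functional assay on MT2 cells (Homo sapiens) for cytotoxicity, read by MTT assay; on this read-out lower numbers stand for higher toxicity in this test and higher numbers for lower toxicity in this test. In this assay compound 1 reaches only the limit of > 100000 nM, which is a limit and not a number. Compound 3 `Cc1cc(C)cc(Cc2nnc(Nc3ccc(Cl)cc3)o2)c1` likewise gives only a limit in this assay, > 100000 nM. Compound 2 `COc1cc(Nc2nnc(Cc3c(Cl)cccc3Cl)o2)c(Cl)cc1Cl` gives 9000 nM in this assay. Compound 1 therefore stands at the limit of > 100000 nM in this assay, at which 2 of the 3 values shown sit. Compound 4 `FC(F)(F)c1cc(Nc2nnc(Cc3c(Cl)cccc3Cl)o2)ccc1Cl` differs from compound 1 by one change: trifluoromethyl in place of methyl on an aromatic carbon. Among the compounds with values here, no measured pair in this set shares that change; the size of the step is not given by the other compounds. The step of an at least 1.2-fold lower number from compound 1 to compound 4 (0.09 log units; that floor lies within the scatter) is expected to be small, if anything beyond the scatter. Compound 4 is therefore expected to give about 80000 nM in this assay, with a range from 20000 nM to 300000 nM.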

Compound 4, half-maximal cytotoxic concentration: 9000 nM
Beside the measured number, compound 4's estimate is 8.9-fold (0.95 log units) above it; the whole stated range lies above it.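

This position is not indifferent in this test: trifluoromethyl in place of methyl on the aromatic carbon ortho to a chloro group gives an at least 11-fold lower number from compound 1 to compound 4 (1.04 log units; beyond the scatter) in this assay, so compound 4 is the more toxic of the two. The true size of the step is unknown, since compound 1 reaches only a limit and not a number: the limit of > 100000 nM in this assay, at which 2 of the 4 values shown sit.

On these data alone, whether an amine or a longer chain at this place would also lower the number stays open. So does whether the same change would act alike in compound 3, which carries no such methyl beside a chloro group.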